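The source may report more compounds than this note shows. Statements on the series, on what has been measured and on what is new or still open speak of the compounds shown alone.

Working notes on the series, following the change from compound 3 to compound 4.

In a physicochemical assay for solubility, read by HPLC, using the shake flask method, measured as kinetic solubility, with a stated time of 20 h, at pH 6.5, tested at 200 uM (on this read-out higher numbers stand for higher solubility and lower numbers for lower solubility), compound 3 `CS(=O)(=O)c1cccc(-c2ccc3nccc(-c4ccncc4)c3n2)c1` gives only a limit, < 5000 nM. Compound 1 `O=S(=O)(c1cccc(-c2ccc3nccc(-c4ccncc4)c3n2)c1)N1CCC(O)CC1` gives 10000 nM in this assay. Compound 2 `Nc1cccc(-c2ccc3nccc(-c4ccncc4)c3n2)c1` gives only a limit in this assay, < 5000 nM. Two of the three values sit at the limit of < 5000 nM in this assay, at which 2 of the 3 values shown sit, so compound 3 stands at the floor of what this assay reports, with no number of its own.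

Compound 4 `CS(=O)(=O)c1cccc(-c2ccc3nccc(N4CCNCC4)c3n2)c1` differs from compound 3 by piperazin-1-yl in place of pyridin-4-yl on an aromatic carbon. Among the measured compounds shown here, none of the measured steps touches this position: an at least 2.0-fold lower number from compound 1 to compound 2 (0.30 log units; that floor lies within the scatter) and an at least 2.0-fold lower number from compound 1 to compound 3 (0.30 log units; that floor lies within the scatter) both concern the group on the other aromatic ring, and a step that the two limits leave unreadable from compound 2 to compound 3 is not readable. For the measured compounds named here, their size therefore sets no expectation for this step. Going by the values given here, with no measured step bearing on it, the estimate for compound 4 rests on compound 3 alone, and a step of an at least 1.6-fold higher number from compound 3 to compound 4 (0.20 log units; that floor lies within the scatter) is expected, upward from the limit of compound 3. Compound 4 is estimated at 8000 nM, in the range 2500 nM to 30000 nM, with a fair chance that this assay again reports only a limit.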

Compound 4, solubility: 165000 nM
Compound 4: middle estimate off by 21-fold (1.31 log units), on the low side, outside the stated range (above it).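

The position opposite the ring nitrogen carries a large effect in this assay: an at least 33-fold higher number from compound 3 to compound 4 (1.51 log units; beyond the scatter), the only step shown at this place, and it lies beyond the scatter, whereas the readable earlier steps, all on the other aromatic ring, are floors within it. The change replaces a six-membered aromatic ring with a six-membered non-aromatic ring and adds a hydrogen-bond donor. The size of the step is itself only a floor, since compound 3 gives a limit and no number: the limit of < 5000 nM in this assay, at which 2 of the 4 values shown sit.

The compounds shown do not separate the loss of the aromatic ring from the gain of the ring amine hydrogen, a comparison that morpholin-4-yl or piperidin-1-yl at this place would address. They also leave open whether the step holds with (4-hydroxypiperidin-1-yl)sulfonyl on the other aromatic ring in place of methylsulfonyl.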